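A few compounds are considered here, and "the series" means these few. Any claim that something is new, unique, unknown or untested is made for them only; others in the source may bear on it.

Working notes on the carboxylic acid series

Compound 1 `CCCCN(C)C(=O)OCc1c(-c2ccc(O[C@H]3CCC[C@H](C(=O)O)C3)c(C)n2)nnn1C` is compared here in an ADME assay on the whole organism (plasma, Homo sapiens) for protein binding, read by LC-MS, with a stated time of 24 h (on this read-out lower numbers stand for a smaller free fraction and higher numbers for a larger free fraction), with two other members of the series. In this assay compound 1 gives 0.026, the largest unbound fraction of the three measured compounds. Compound 2 `CN(C(=O)OCc1c(-c2ccc(O[C@H]3CCC[C@H](C(=O)O)C3)cc2)cnn1C)C1CCCC1` gives 0.009 in this assay, the nearest value to compound 1, and the gap lies beyond the usual scatter. Compound 3 `Cc1noc(-c2ccc(O[C@H]3CCC[C@H](C(=O)O)C3)cc2)c1CNC(=O)OCCC(C)(C)C` gives 0.006 in this assay, the value furthest from compound 1, also beyond the scatter. Compound 2 and compound 3 carry different cores from compound 1, so none of these pairs is a single-point step, and only the values themselves are shown.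

Compound 4 `Cc1nc(-c2nnn(C)c2COC(=O)N(C)CC2CCC2)ccc1O[C@H]1CCC[C@H](C(=O)O)C1` has not yet been measured in this assay. It differs from compound 1 in one place: cyclobutyl in place of propyl on a saturated chain carbon bound to an amide-type nitrogen. Going by the values given here, the change adds one carbon and closes a ring on the chain of the carbamate nitrogen, and no measured pair in the set isolates this kind of change.

With only this to go on, a small downward step, likely within the scatter, is the expectation for the step of a 1.3-fold lower number from compound 1 to compound 4 (0.11 log units; within the scatter). Compound 4 is therefore estimated to give 0.02 in this assay, with a range from 0.01 to 0.035.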

Compound 4, unbound fraction: 0.033
Compound 4: middle estimate off by 1.7-fold (0.22 log units), on the low side; low and high end bracket the measured number.
By their numbers in this assay, from the lowest: compounds 3 and 2 (each within the scatter of the next); then compounds 1 and 4 (each within the scatter of the next).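

In this assay the change from propyl to cyclobutyl, on a saturated chain carbon bound to an amide-type nitrogen, gives a 1.3-fold higher number from compound 1 to compound 4 (0.10 log units; within the scatter) and so leaves the unbound fraction of this pair unresolved from the scatter. Going by these compounds alone, this is the first single-place step: the earlier comparisons all crossed different cores and could not separate the chain from the rest of the molecule, whereas here the core of compound 1 is held constant and the butyl to cyclobutylmethyl exchange, with its extra carbon and four-membered ring, shifts the read-out by no more than repeated measurement would. No measurement at hand bears on what lies behind this outcome.

As far as these compounds go, how far this tolerance extends at this place remains open, since a longer chain such as octyl, a cyclohexylmethyl group or a chain ending in an amine could behave quite differently from the two groups compared here. Also open, from the compounds shown here alone, is whether the same exchange would read the same way on the cores of compound 2 and compound 3, which carry other chains on their carbamates.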